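The source may hold more compounds than are shown below. What is called first, only, known or untested is meant among the compounds shown, and "the series" means these compounds.

The measured compounds in an ADME assay on Raji cells (Homo sapiens) for cytotoxicity, read by CellTiter-Glo and resazurin assay, with a stated time of 72 h; a higher number here means that more compound is needed for the effect, a lower number that less compound is needed:

Compound 1, `CC(C)N(Cc1cccc(OCCCCCC(=O)O)c1)C(=O)c1ccccc1`, gives > 26000 nM in this assay, a limit of the assay and not a number.
Compound 2, `CC(C)N(Cc1cccc(OCCCCCC(=O)O)c1)C(=O)c1ccc(-c2cccc(-c3ccccc3)c2)cc1`, gives > 26000 nM in this assay, likewise a limit.
Compound 3, `CC(C)N(Cc1cccc(OCCCCCC(=O)O)c1)C(=O)c1ccc(-c2ccoc2)cc1`, gives > 26000 nM in this assay, again a limit.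

Compound 3 therefore stands at a limit, and nothing separates it from the other two compounds on the numbers shown: the limit of > 26000 nM in this assay, at which 3 of the 3 values shown sit. The three steps between them are unreadable for the same reason, a step that the two limits leave unreadable from compound 1 to compound 2, a step that the two limits leave unreadable from compound 1 to compound 3 and a step that the two limits leave unreadable from compound 2 to compound 3, so none of them gives a size or a direction.

Compound 4, `CC(C)N(Cc1cccc(OCCCCCC(=O)O)c1)C(=O)c1ccc(-c2cccc(O)c2)cc1`, differs from compound 3 in one place: 3-hydroxyphenyl in place of furan-3-yl on an aromatic carbon. Within the data shown here, the steps that bear on this change, from a hydrogen or a furan-3-yl or a 3-phenylphenyl to another group on the same aromatic carbon, were all unreadable, so no step beyond the scatter can be expected in this assay in either direction, and the most likely outcome for compound 4 is again a limit. The expected step that the limit leaves unreadable from compound 3 to compound 4 is therefore close to none. Compound 4 is estimated at 30000 nM, in a range from 13000 nM to 80000 nM.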

Compound 4, half-maximal effective concentration: > 26000 nM
Compound 4 gave a limit, no number; the forecaster's own chance of this, stated with the estimate: 80%; the middle value does not contradict the limit.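

Among these compounds, compound 4 gives only a limit in this assay and not a number, so no step between compound 1, compound 2, compound 3 and compound 4 can be read: the limit of > 26000 nM in this assay, at which 4 of the 4 values shown sit. The compounds shown leave open whether any of these groups on the aromatic carbon changes the concentration needed for the effect, and in which direction.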